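Chain variation at the ring amine of the shared core

The compounds below may be only part of what the source reports. "The series", "measured", "known", "first", "only" and "open" are said of these compounds alone.

Among the compounds with values here, compound 2 `COc1cc(N)c(Cl)cc1C(=O)NC1CCN(CC2CCN(CCCCN)CC2)CC1` holds the lower of the two numbers measured so far in an assay on striatum for inhibition of 5-hydroxytryptamine receptor 4 (Cavia porcellus), read by radioligand binding; on this read-out higher numbers stand for weaker inhibition and lower numbers for stronger inhibition: compound 2 gives 6.47 nM. Within the data shown here, compound 1 `COc1cc(N)c(Cl)cc1C(=O)NC1CCN(CC2CCN(CCCNS(C)(=O)=O)CC2)CC1` gives 21.1 nM, and the one measured step, a 3.3-fold lower number from compound 1 to compound 2 (0.51 log units; beyond the scatter), is the only comparison available.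

Compound 3 `COc1cc(N)c(Cl)cc1C(=O)NC1CCN(CC2CCN(CC(O)CN)CC2)CC1` differs from compound 2 by 2-amino-1-hydroxyethyl in place of 3-aminopropyl on a saturated chain carbon bound to an amine nitrogen in a ring. Among the measured compounds shown here, no measured step matches this change: the step from compound 1 to compound 2 altered the group at the end of the chain while keeping the chain itself, whereas here the chain is shortened and a hydroxyl enters on the carbon bound to the ring nitrogen, with the amine retained. That earlier step shows the tail region tolerates variation with modest effect, so a change of comparable size is plausible, but its direction cannot be read from the data. The estimate for compound 3 is therefore a step of a 1.7-fold higher number from compound 2 to compound 3 (0.23 log units; within the scatter) in this assay, leaning toward a somewhat higher number because compound 2 already sits at 6.47 nM, the lowest value seen. Compound 3 is expected at 11 nM, within a range from 3.5 nM to 35 nM.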

Compound 3, half-maximal inhibitory concentration: 14.4 nM
Compound 3: the middle estimate sits 1.3-fold (0.12 log units) below what was measured; the measured number falls inside the stated range.
By their numbers in this assay, from the lowest: compound 2; then compounds 3 and 1 (each within the scatter of the next).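

In this assay, 2-amino-1-hydroxyethyl in place of 3-aminopropyl on a saturated chain carbon bound to an amine nitrogen in a ring gives a 2.2-fold higher number from compound 2 to compound 3 (0.35 log units; beyond the scatter) in a change that retains the amine, so this position responds to more than the change of end group seen in the earlier step. Set against the chain of compound 1, the same group gives a 1.5-fold lower number from compound 1 to compound 3 (0.17 log units; within the scatter) and this read-out does not separate the two, even though 2-amino-1-hydroxyethyl and 2-(methanesulfonamido)ethyl end in different groups. Nothing on hand offers an explanation for either step.

The step from the 3-aminopropyl chain merges two changes, a shorter chain and the entry of a hydroxyl, and a 2-aminoethyl chain without the hydroxyl would be needed to read them apart. Going by these compounds, how a dimethylamino end group, a carboxylic acid or a longer chain such as 5-aminopentyl would read at this place also stays open.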